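Lengthening the Alkenyl Chain on the Amide of Compound 2

The compounds below may be only part of what the source reports. "The series", "measured", "known", "first", "only" and "open" are said of these compounds alone.

Of the compounds shown here, two have been tested so far in a functional assay on HeLa cells (Homo sapiens) for inhibition, read by MTT assay, with a stated time of 72 h; on this read-out lower numbers stand for stronger inhibition and higher numbers for weaker inhibition. Compound 1 `COc1cccc(Nc2nc(Oc3cccc(NC(=O)/C=C/C(C)C)c3)c3sccc3n2)c1` gives 27000 nM in this assay. Compound 2 `CC(C)=CC(=O)Nc1cccc(Oc2nc(Nc3cccc(C#N)c3)nc3ccsc23)c1` gives 19800 nM in this assay. Compound 2 thus has the smaller of the two numbers, but its gap to compound 1 lies within the usual scatter of repeated measurements, so the two cannot be told apart on this evidence. Compound 3 `CC(C)/C=C/C(=O)Nc1cccc(Oc2nc(Nc3cccc(C#N)c3)nc3ccsc23)c1` has not yet been measured. It differs from compound 2 in one place: 3-methylbut-1-en-1-yl in place of 2-methylprop-1-en-1-yl on a carbonyl carbon. Within the data shown here, no measured pair shows the effect of this particular change on its own, and the one compound that carries the longer chain, compound 1, also differs elsewhere. The step from compound 2 to compound 3 is expected to be small, in either direction or none beyond the scatter, at a 1.1-fold higher number from compound 2 to compound 3 (0.05 log units; within the scatter). Compound 3 is therefore estimated at 22000 nM in this assay, within a range from 8000 nM to 60000 nM.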

Compound 3, half-maximal inhibitory concentration: 36500 nM
For compound 3 the middle estimate is 1.7-fold (0.22 log units) below the measured one, and the stated range covers the measured number.
By their numbers in this assay, from the lowest: compounds 2, 1 and 3 (each within the scatter of the next).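

In this assay, among these compounds, 3-methylbut-1-en-1-yl in place of 2-methylprop-1-en-1-yl on the carbonyl carbon gives a 1.8-fold higher number from compound 2 to compound 3 (0.27 log units; within the scatter) and so provides the first reading of this change on its own, with no separation between the two compounds. Among the compounds shown here, compound 3 also carries the same chain as compound 1, which isolates cyano in place of methoxy on an aromatic carbon for the first time, and that swap gives a 1.4-fold higher number from compound 1 to compound 3 (0.13 log units; within the scatter) with no separation either. No supporting evidence bears on these results.

Still open, going by these compounds, is whether a saturated chain or a phenyl ring in place of the alkenyl chain on the carbonyl carbon would move the number beyond the scatter. The same question applies to a carboxylic acid or an amine in place of cyano on the aromatic carbon.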